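Acetoxy Substitution Compared on Two Related Cores

The compounds below may be only part of what the source reports. "The series", "measured", "known", "first", "only" and "open" are said of these compounds alone.

Compound 2 `CC1=C(CCc2ccoc2)[C@@]2(C)CCCC(C)(C)[C@@H]2[C@H](O)C1=O` carries the shared core without the group in question. In a functional assay on RAW264.7 cells (Mus musculus) for inhibition, read by Griess assay, with stated times of 2 h and 18 h (on this read-out lower numbers stand for stronger inhibition and higher numbers for weaker inhibition), compound 2 gives > 50000 nM, which is a limit of the assay and not a number. Compound 1 `CC(=O)O[C@@H]1CC[C@]2(C)C(CCc3ccoc3)=C(C)C(=O)[C@@H](O)[C@H]2C1(C)C` adds the group; in this assay compound 1 gives 22500 nM. The change acetoxy in place of hydrogen on a saturated ring carbon produced an at least 2.2-fold lower number from compound 2 to compound 1 (0.34 log units; beyond the scatter), a step known only as a bound because of the limit of > 50000 nM in this assay, at which 1 of the 3 values shown sits. Compound 3 `CCC(=O)[C@H]1O[C@@](CCC2=CC(OC)OC2=O)(OC)[C@@]2(C)CCCC(C)(C)[C@H]12` rests on a different core; the difference between the two cores is not broken down here. In this assay compound 3 gives 3900 nM, the lowest of the two numbers measured, with compound 1 the nearest. Compound 4 `CCC(=O)[C@H]1O[C@@](CCC2=CC(OC)OC2=O)(OC)[C@@]2(C)CC[C@@H](OC(C)=O)C(C)(C)[C@H]12` has not yet been measured in this assay. It differs from compound 3 by acetoxy in place of hydrogen on a saturated ring carbon, the same change as from compound 2 to compound 1, since the place is described in the same words. Compound 4 is therefore expected to show a 2.2-fold lower number from compound 3 to compound 4 (0.34 log units; beyond the scatter). That expectation rests on an at least 2.2-fold lower number from compound 2 to compound 1 (0.34 log units; beyond the scatter) and on the number compound 3 gives, 3900 nM. Compound 4 is estimated at 1800 nM, between 700 nM and 5000 nM.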

Compound 4, half-maximal inhibitory concentration: > 50000 nM
Compound 4: a limit, no number; the forecaster's own chance of this, stated with the estimate: 2%; at least 27-fold (1.44 log units) between middle value and limit.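

Carried to the core of compound 3, acetoxy in place of hydrogen on a saturated ring carbon gave an at least 12-fold higher number from compound 3 to compound 4 (1.10 log units; beyond the scatter) in this assay, so in this assay the change did not transfer from one core to the other, and the two steps point in opposite directions: the same change on two cores in this assay, an at least 2.2-fold lower number (0.34 log units; beyond the scatter) from compound 2 to compound 1 and an at least 12-fold higher number (1.10 log units; beyond the scatter) from compound 3 to compound 4, at least 28-fold (1.45 log units) apart, beyond the scatter of two such steps

Compound 4 stands at a limit of the assay and not at a number, so the true size of this step remains unknown, as does that of the earlier one: the limit of > 50000 nM in this assay, at which 2 of the 4 values shown sit.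

These two pairs show that the result of this change depended on the core in this assay, but they do not show which difference between the cores is responsible, nor how the change would behave on any further core.

The compounds shown leave open whether a hydroxy group or a longer ester such as butyryloxy on the same ring carbon would also split between the two cores. They also leave open whether the furan ring alone, placed on the core of compound 3, would alter the outcome.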